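The source may hold more compounds than are shown below. What is called first, only, known or untested is meant among the compounds shown, and "the series" means these compounds.

Of the compounds shown here, three have been measured in a functional assay on DLD-1 cells (Homo sapiens) (a lower number here means a stronger inhibitor, a higher number a weaker inhibitor), and all share one core. Compound 1 `CC(C)C/N=C(\S)N1CCN(c2ccc(N(Cc3c[nH]cn3)S(=O)(=O)c3ccccc3)cc2)CC1` gives 800 nM. Compound 2 `N#Cc1ccc(Cn2cncc2CN(c2ccc(N3CCN(C(=O)c4ccc(Cl)s4)CC3)cc2)S(=O)(=O)c2ccccc2)cc1` gives 200 nM, the second highest of the three numbers; its nearest neighbour is compound 1, and its furthest is compound 3 `N#Cc1ccc(Cn2cncc2CN(C(=O)c2cccc(Cl)c2)c2ccc(N3CCN(C(=O)c4ccc(Cl)s4)CC3)cc2)cc1`, which gives 2 nM. Among the measured compounds shown here, the one step between neighbours that differ in a single place is a 100-fold lower number from compound 2 to compound 3 (2.00 log units; beyond the scatter).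

Compound 4 `COc1cccc(C(=O)N(Cc2cncn2Cc2ccc(C#N)cc2)c2ccc(N3CCN(C(=O)c4ccc(Cl)s4)CC3)cc2)c1` has not been measured. It differs from compound 2 by (3-methoxyphenyl)carbonyl in place of phenylsulfonyl on a nitrogen on an aromatic ring. For the measured compounds named here, the step that bears on it is the one from compound 2 to compound 3, where the same phenylsulfonyl group was replaced by a (3-chlorophenyl)carbonyl group on the same nitrogen, a 100-fold lower number from compound 2 to compound 3 (2.00 log units; beyond the scatter). Because that step a 100-fold lower number from compound 2 to compound 3 (2.00 log units; beyond the scatter) was large, a large lowering is expected here too, though the group entering carries a methoxy rather than a chloro, so the size is less certain. The expected step is a 33-fold lower number from compound 2 to compound 4 (1.52 log units; beyond the scatter). For compound 4 the estimate in this assay is 6 nM, with a range from 1.5 nM to 30 nM.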

Compound 4, half-maximal inhibitory concentration: 7 nM
For compound 4 the middle estimate is 1.2-fold (0.07 log units) below the measured one; measured number inside the range.
By their numbers in this assay, from the lowest: compound 3; then compound 4; then compound 2; then compound 1.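

In this assay the large gain from leaving phenylsulfonyl is not tied to the chloro group: (3-methoxyphenyl)carbonyl on the same nitrogen gives a 29-fold lower number from compound 2 to compound 4 (1.46 log units; beyond the scatter) and so keeps most of it. The group on the aromatic ring still counts, since methoxy in place of chloro gives a 3.5-fold higher number from compound 3 to compound 4 (0.54 log units; beyond the scatter) and this modest step lies beyond the scatter. No measurement at hand explains either step.

From the compounds shown here alone, both carbonyl compounds swap the sulfonyl for a carbonyl and also add a group to the phenyl ring, so the share of each change stays open. A plain phenylcarbonyl group or a (3-chlorophenyl)sulfonyl group on this nitrogen would separate the two, and a fluoro or an amine on the ring would show how far the ring group matters.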